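A few compounds are considered here, and "the series" means these few. Any claim that something is new, unique, unknown or untested is made for them only; others in the source may bear on it.

Measured compounds in this series:

compound 1 `CCCCOCCn1c(N2CCCN(C)CC2)nc2ccccc21`, 10 nM
compound 2 `C=CCOCCn1c(N2CCCN(C)CC2)nc2ccccc21`, 10 nM
compound 3 `CCCCN1CCCN(c2nc3ccccc3n2CCOCC)CC1`, 8.4 nM

In a functional assay on ileum for inhibition of histamine H1 receptor (Cavia porcellus) (on this read-out higher numbers stand for weaker inhibition and lower numbers for stronger inhibition), compound 2 stands level with compound 1 at the digits shown; the two together hold the highest numbers of the three. Compound 3 gives 8.4 nM, which differs from the number of compound 2 only within the scatter, so no order between them can be drawn.

Compound 4 `CCCOCCn1c(N2CCCN(C)CC2)nc2ccccc21` differs from compound 2 by ethyl in place of vinyl on a saturated chain carbon bound to an oxygen on a saturated carbon. Going by the values given here, the one measured step that bears on this position is no change at the digits printed from compound 1 to compound 2 (within the scatter), where the chain on the oxygen was shortened and unsaturated without any shift in the number. The present change, vinyl to ethyl, keeps the chain length and removes the double bond; the saturated propyl of compound 1 and the vinyl of compound 2 bracket it on both sides and read alike. No step beyond the scatter is therefore expected in this assay, in either direction. Compound 4 is expected to give 10 nM, in the range 5 nM to 20 nM. The expected step of no change at the digits printed from compound 2 to compound 4 (within the scatter) is estimated to stay within the scatter.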

Compound 4, half-maximal inhibitory concentration: 16 nM
The estimate for compound 4 lay 1.6-fold (0.20 log units) below the measured number; the range from low to high includes it.
By their numbers in this assay, from the lowest: compounds 3, 1, 2 and 4 (each within the scatter of the next).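

In this assay the saturated propoxy chain reads alike with the allyloxy and butoxy chains at this position, as shown by a 1.6-fold higher number from compound 2 to compound 4 (0.20 log units; within the scatter) and by a 1.6-fold higher number from compound 1 to compound 4 (0.20 log units; within the scatter). The first step shows that removing the double bond outside aromatic rings gives no difference that can be separated from the scatter, and the second shows the same for hydrogen in place of methyl on a saturated chain carbon, three bonds along the chain from an oxygen on a saturated carbon. No measurement at hand accounts for these readings.

Still open, as far as these compounds go, is whether the position tolerates an amine, a carboxylic acid or a much longer chain, as only allyl, propyl and butyl on the oxygen can be compared here. Compound 3 differs from these compounds in more than one place and cannot settle this.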